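Fluoro for carbamoyl on the fused aryl of compound 2

The source may report more compounds than this note shows. Statements on the series, on what has been measured and on what is new or still open speak of the compounds shown alone.

Compound 2 `CCC1C(=O)N(C)c2cnc(-n3ccc4cc(C(N)=O)ccc43)nc2N1c1ccn(C)n1` carries a carbamoyl on the fused aryl and is reported in a functional assay on MCF7 cells (Homo sapiens) for antiproliferative activity, read by CCK-8 assay, with a stated time of 72 h (on this read-out higher numbers stand for weaker inhibition of growth and lower numbers for stronger inhibition of growth), as "not active" (no number reported), without a single number. Compound 1 `CC[C@@H]1C(=O)N(C)c2cnc(-n3ccc4cc(F)ccc43)nc2N1C1CCCC1`, which carries the fluoro on the same fused aryl but a cyclopentyl in place of the methylpyrazolyl, is likewise reported in this assay as "not active" (no number reported). Among the measured compounds shown here, the only numbered entry is compound 3 `CCC1C(=O)N(C)c2cnc(Nc3ccc(S(=O)(=O)NCCCO)cc3)nc2N1c1ccn(C)n1`, which in this assay gives 21600 nM; its anilino-sulfonamide side differs from compound 2 in more than one place, so no step is counted between them. Compound 4 `CCC1C(=O)N(C)c2cnc(-n3ccc4cc(F)ccc43)nc2N1c1ccn(C)n1` keeps the core and the methylpyrazolyl of compound 2 and differs only by fluoro in place of carbamoyl on an aromatic carbon. For the measured compounds named here, with no number for compound 2 and no step recorded, the size of the change in this assay cannot be read from the series; the expectation is of no movement beyond the scatter, with compound 4 most likely again returned without a number. Compound 4 is estimated in this assay at 40000 nM, within 10000 nM to 150000 nM.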

Compound 4, concentration for 50% growth inhibition: 24700 nM
Compound 4: the middle estimate sits 1.6-fold (0.21 log units) above what was measured; low and high end bracket the measured number.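

In this assay, among the compounds shown here, compound 2 stands as "not active" (no number reported) and compound 4 gives 24700 nM, so no step between these two compounds can be read. Nothing measured here bears on this result. The compounds shown leave open how far fluoro in place of carbamoyl shifts growth inhibition.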